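This account rests on a few compounds, and the source may have more. Where it says the series, first, only, none or still open, it means among the compounds named here.

In a functional assay on COLO 205 cells (Homo sapiens) for antiproliferative activity, read by MTT assay, with a stated time of 68 h (a lower number here means a stronger inhibitor, a higher number a weaker inhibitor), compound 3 `O=S(=O)(Nc1ccc(F)c(C#Cc2cnc3[nH]nc(-c4ccccc4)c3c2)c1F)c1cccnc1` gives 200 nM, the second highest of three numbers. Its nearest neighbour is compound 2 `Cc1n[nH]c2ncc(C#Cc3c(F)ccc(NS(=O)(=O)c4cccnc4)c3F)cc12`, which gives 148 nM in this assay, a difference within the scatter; the furthest is compound 1 `O=S(=O)(Nc1ccc(F)c(C#Cc2cnc3[nH]ncc3c2)c1F)c1ccccc1F`, which gives 534 nM, a difference beyond it. Compound 4 `O=S(=O)(Nc1ccc(F)c(C#Cc2cnc3[nH]nc(-c4ccc(F)cc4)c3c2)c1F)c1cccnc1` differs from compound 3 by fluoro in place of hydrogen on an aromatic carbon. For the measured compounds named here, the only measured step touching this part of the shared core is a 1.4-fold higher number from compound 2 to compound 3 (0.13 log units; within the scatter), which stayed within the scatter. Going by the values given here, no measured step adds a fluorine anywhere, so there is no direct guide. Given that small change, the step is expected to stay within the scatter, no change at the digits printed from compound 3 to compound 4 (within the scatter). Compound 4 is therefore estimated at 200 nM, with a range from 80 nM to 500 nM.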

Compound 4, half-maximal inhibitory concentration: 166 nM
Beside the measured number, compound 4's estimate is 1.2-fold (0.08 log units) above it; the measured number falls inside the stated range.
By their numbers in this assay, from the lowest: compounds 2, 4 and 3 (each within the scatter of the next); then compound 1.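

In this assay, putting fluoro on the phenyl group, para to a large group, gives a 1.2-fold lower number from compound 3 to compound 4 (0.08 log units; within the scatter), so this position takes a single fluorine with no shift that can be told from the scatter. Replacing methyl with the whole 4-fluorophenyl group gives a 1.1-fold higher number from compound 2 to compound 4 (0.05 log units; within the scatter), which also stays within the scatter. No evidence is available to explain why these numbers stay so close. Still open, from the compounds shown here alone, is whether a larger group at this place, such as an amine or a carboxylic acid, would also stay within the scatter.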